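Swapping 4-propylpiperazin-1-yl for Dimethylamino

The source may hold more compounds than are shown below. What is called first, only, known or untested is meant among the compounds shown, and "the series" means these compounds.

Within the data shown here, in a functional assay on A549 cells (Homo sapiens) for cytotoxicity, read by MTT assay, with a stated time of 72 h (on this read-out higher numbers stand for weaker inhibition and lower numbers for stronger inhibition), compound 2 `CCCN1CCN(CCCCn2c3c(c4ccccc42)C(=O)c2c[n+]([O-])c4ccccc4c2C3=O)CC1` gives 320 nM, the lower of the two numbers so far. Compound 1 `O=C1c2c[n+]([O-])c3ccccc3c2C(=O)c2c1c1ccccc1n2Cc1cn(C[C@H](O)CO)nn1` gives 1030 nM on the same read-out, so compound 2 stands as the stronger inhibitor of the pair.

Compound 3 `CN(C)CCCCn1c2c(c3ccccc31)C(=O)c1c[n+]([O-])c3ccccc3c1C2=O` has not yet been measured. It keeps the core of compound 2 but carries dimethylamino in place of 4-propylpiperazin-1-yl on a saturated chain carbon, four bonds along the chain from an aromatic nitrogen.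

Among the measured compounds shown here, only one measured step bears on this change: a 3.2-fold lower number from compound 1 to compound 2 (0.51 log units; beyond the scatter). That modest step replaced a different group, so it offers only a rough guide to size. For the measured compounds named here, no measured pair shows the effect of this exchange alone. With so little evidence, no shift beyond the usual scatter is expected in this assay, and no direction can be favoured with confidence. The expected change is a 1.1-fold higher number from compound 2 to compound 3 (0.04 log units; within the scatter). For compound 3 the estimated value is 350 nM, with an expected range of 130 nM to 900 nM.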

Compound 3, half-maximal inhibitory concentration: 310 nM
The estimate for compound 3 lay 1.1-fold (0.05 log units) above the measured number; the range from low to high includes it.
By their numbers in this assay, from the lowest: compounds 3 and 2 (each within the scatter of the next); then compound 1.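

In this assay, cutting 4-propylpiperazin-1-yl down to dimethylamino on a saturated chain carbon, four bonds along the chain from an aromatic nitrogen, gives a 1.0-fold lower number from compound 2 to compound 3 (0.01 log units; within the scatter) as its step, so at this position the loss of the six-membered ring and of most of the group's heavy atoms leaves the number within the scatter. The step to compound 2 had left open whether the gain over compound 1 depended on the piperazine ring, but a 3.3-fold lower number from compound 1 to compound 3 (0.52 log units; beyond the scatter) is of much the same modest size as a 3.2-fold lower number from compound 1 to compound 2 (0.51 log units; beyond the scatter) and shows that the ring is not needed for that gain in this pair of amines. No measured evidence accounts for this result.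

From the compounds shown here alone, whether this tolerance extends beyond these two tertiary amines remains open, since a primary amine, a morpholine or a carboxylic acid at the end of the same chain could behave differently. It is also unknown how dimethylamino would fare on a shorter or longer chain, which would show whether the distance from the aromatic nitrogen matters as little as the size of the amine does here.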